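This account rests on a few compounds, and the source may have more. Where it says the series, first, only, none or still open, it means among the compounds named here.

Measured in a physicochemical assay for lipophilicity; a higher number here means a more lipophilic compound, a lower number a more polar compound:
- compound 1 `COC[C@H](Oc1ncnc2c1cnn2-c1ccccc1Cl)C(=O)Nc1ccc(C)cn1`: 3.4
- compound 2 `COC[C@H](Oc1ncnc2c1cnn2-c1ncccc1Cl)C(=O)Nc1cnc(C)cn1`: 1.4
- compound 3 `CCOC[C@H](Oc1ncnc2c1cnn2-c1ncccc1Cl)C(=O)Nc1cnc(C)cn1`: 1.8

Compound 2 stands lowest of these three, at 1.4. Compound 4 `COC[C@H](Oc1ncnc2c1cnn2-c1ncccc1Cl)C(=O)Nc1ccc(C)cn1` differs from compound 2 in one place: 5-methylpyridin-2-yl in place of 5-methylpyrazin-2-yl on an amide-type nitrogen.

Among the compounds with values here, no measured step covers this exchange on its own. Within the data shown here, the only measured step between compounds differing in one place is a number 0.40 log units higher from compound 2 to compound 3 (beyond the scatter). It comes from a methyl in place of hydrogen on a saturated chain carbon, a different change, so it offers only a sense of scale.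

The closest clue is compound 1, which also carries 5-methylpyridin-2-yl on an amide-type nitrogen and gives 3.4. Compound 1 has other structural differences as well, so its whole gap from compound 2 cannot be credited to this exchange. With compound 1 at 3.4, an upward move is expected, probably somewhat larger than the modest step seen for compound 3, yet well short of that whole gap.

The expected change is a number 0.70 log units higher from compound 2 to compound 4 (beyond the scatter). For compound 4 the estimated value is 2.1, with an expected range from 1.7 to 2.6.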

Compound 4, distribution coefficient: 2.3
Estimate against measurement, compound 4: 0.20 log units below; the measured number falls inside the stated range.
By their numbers in this assay, from the lowest: compound 2; then compound 3; then compound 4; then compound 1.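

In this assay, exchanging 5-methylpyrazin-2-yl for 5-methylpyridin-2-yl on the amide-type nitrogen gives a number 0.90 log units higher from compound 2 to compound 4 (beyond the scatter) with the rest of the molecule unchanged, so this single exchange now has a size of its own, which compound 1 could not show because it also differs from compound 2 elsewhere. Compound 4 also isolates the second difference, since 3-chloropyridin-2-yl in place of 2-chlorophenyl on the aromatic nitrogen gives a number 1.10 log units lower from compound 1 to compound 4 (beyond the scatter) and shows that both exchanges move the number, with the compound that has carbon in place of a ring nitrogen reading higher in each of these two steps. Nothing measured here accounts for the size of either step.

As far as these compounds go, whether the pyrazine-to-pyridine exchange gives a similar step on compound 3, with its longer chain, remains open. Also open, from the compounds shown here alone, is how the number would move if an amine or a carboxylic acid replaced the methyl on the ring attached to the amide-type nitrogen.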